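A Second Chloro on the Sulfone-Bearing Ring

This account rests on a few compounds, and the source may have more. Where it says the series, first, only, none or still open, it means among the compounds named here.

Compound 1, `CN1CCN(c2ccc3[nH]nc(S(=O)(=O)c4ccccc4Cl)c3c2)CC1`, stands at the stronger end of the two compounds measured in an assay on HeLa cells for displacement of a labelled ligand from 5-hydroxytryptamine receptor 6 (Homo sapiens); on this read-out higher numbers stand for weaker inhibition and lower numbers for stronger inhibition: compound 1 gives 4 nM. The other measured compound, compound 2, `O=S(=O)(c1cccc2ccccc12)c1n[nH]c2cccc(N3CCNCC3)c12`, gives 48 nM in this assay, a number well beyond the usual scatter above that of compound 1. Compound 3, `CN1CCN(c2ccc3[nH]nc(S(=O)(=O)c4c(Cl)cccc4Cl)c3c2)CC1`, is not yet measured. It differs from compound 1 in one place: chloro in place of hydrogen on an aromatic carbon. The chloro enters on an aromatic carbon of a six-membered aromatic ring of carbon only, ortho to a large group and meta to a chloro group, so that 2-chlorophenyl becomes 2,6-dichlorophenyl. Going by the values given here, no measured pair shows this change, so there is no direct guide to its effect. Because compound 1 already sits at 4 nM, only a modest shift, within the scatter, is expected. The expected step is a 1.3-fold higher number from compound 1 to compound 3 (0.10 log units; within the scatter). For compound 3 the estimated value is 5 nM, with a range from 1.5 nM to 16 nM.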

Compound 3, inhibition constant: 2.6 nM
For compound 3 the middle estimate is 1.9-fold (0.28 log units) above the measured one, and the stated range covers the measured number.
By their numbers in this assay, from the lowest: compounds 3 and 1 (each within the scatter of the next); then compound 2.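

This carbon of the ring, ortho to a large group and meta to a chloro group, accepts a second chloro without any loss of binding that can be told from scatter. The change from 2-chlorophenyl to 2,6-dichlorophenyl gives a 1.5-fold lower number from compound 1 to compound 3 (0.19 log units; within the scatter) in this assay, so the two compounds count as equal on this read-out. A hydrogen at this place is therefore not required for a low number, but nothing shown here explains why the added chlorine atom leaves the binding as it is.

Going by these compounds, one chloro says little about other groups on this carbon, so it remains open whether a methyl, a methoxy or an amine would fit as well. Also open, on these data alone, is what a plain phenyl, with no chloro on the ring at all, would give.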